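The source may hold more compounds than are shown below. What is called first, only, known or untested is meant among the compounds shown, and "the series" means these compounds.

Measured in a functional assay on DU-145 cells (Homo sapiens) for cytotoxicity, in the presence of a further agent that is not named here; on this read-out lower numbers stand for stronger inhibition and higher numbers for weaker inhibition:
- compound 1 `Clc1ccc(-c2cc(-c3ccsc3)nc(-c3ccco3)c2)o1`: 18900 nM
- compound 2 `Clc1ccc(-c2cc(-c3cccnc3)nc(-c3cccs3)c2)o1`: 13000 nM

Compound 1 and compound 2 lie within the scatter of each other, so the numbers give no order between them, and compound 1 has no clear standing beyond sharing this level with compound 2.

Not yet measured is compound 3 `Clc1ccc(-c2cc(-c3ccc(Cl)o3)cc(-c3ccsc3)n2)cc1`, which carries 4-chlorophenyl in place of furan-2-yl on an aromatic carbon of the core of compound 1, next to the ring nitrogen: 4-chlorophenyl in place of furan-2-yl on an aromatic carbon. The 5-chlorofuran-2-yl and thiophen-3-yl groups stay.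

No pair of measured compounds differs in one place only, so the size of this change in this assay has not been shown directly. Among the compounds with values here, the only guide is that compound 1 at 18900 nM and compound 2 at 13000 nM differ in more than one place yet remain within the scatter. A modest move towards stronger inhibition is expected, reaching only a little beyond the scatter, though no change at all remains possible.

The expected step is a 2.4-fold lower number from compound 1 to compound 3 (0.37 log units; beyond the scatter).

For compound 3 the estimated value in this assay is 8000 nM, with an expected range of 2000 nM to 30000 nM.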

Compound 3, half-maximal inhibitory concentration: 19500 nM
The estimate for compound 3 lay 2.4-fold (0.39 log units) below the measured number; measured number inside the range.
By their numbers in this assay, from the lowest: compounds 2, 1 and 3 (each within the scatter of the next).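

Within the data shown here, this is the first single-place comparison: in this assay, 4-chlorophenyl in place of furan-2-yl on this aromatic carbon, next to the ring nitrogen, gives a 1.0-fold higher number from compound 1 to compound 3 (0.01 log units; within the scatter). At this position, the swap from a five-membered aromatic ring with one hetero atom to a six-membered aromatic ring of carbon only, with the hydrogen-bond acceptor of furan-2-yl gone and a chlorine added, shows no shift beyond the scatter, so this aromatic carbon accepts either group at the same level of the read-out. No measured evidence bears on why the two groups sit at this one level.

Open is whether a group of another kind at this carbon, such as an amine or a carboxylic acid on the 4-chlorophenyl ring, would move the number beyond the scatter, since the compounds shown carry only aromatic rings here. Also open, on these data alone, is what the 5-chlorofuran-2-yl and thiophen-3-yl groups contribute, since compound 2 differs from compound 1 in more than one place and gives no single-place reading of either group.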